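A Second Methyl on the Aryl Ring

The source may report more compounds than this note shows. Statements on the series, on what has been measured and on what is new or still open speak of the compounds shown alone.

Two compounds share one core and carry a different aryl group on it. Compound 1 `CCCOc1ccc(-c2cc(=O)c3c(o2)C(CC)(CC)C(=O)C(CC)=C3O)cc1` gives 29.2 uM in a functional assay on KBVIN cells (Homo sapiens) for antiproliferative activity, read by sulforhodamine B assay, with a stated time of 3 days; a higher number here means that more compound is needed for the effect, a lower number that less compound is needed. Compound 2 `CCC1=C(O)c2c(oc(-c3cccc(C)c3)cc2=O)C(CC)(CC)C1=O` gives 3.69 uM in this assay, the lowest of the two numbers and a gap to compound 1 that lies beyond the usual scatter.

Compound 3 `CCC1=C(O)c2c(oc(-c3cc(C)ccc3C)cc2=O)C(CC)(CC)C1=O` is not yet measured. It differs from compound 2 in one place: methyl in place of hydrogen on an aromatic carbon. Cut one bond further out, the aryl group changes from 3-methylphenyl to 2,5-dimethylphenyl.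

Going by the values given here, no measured pair shows what a single added methyl does here, so the expectation rests on compound 2 alone. The step from compound 2 to compound 3 is expected to be small, a 1.1-fold lower number from compound 2 to compound 3 (0.02 log units; within the scatter), not clearly beyond the scatter in either direction. Compound 3 is therefore estimated at 3.5 uM in this assay, within a range from 1.2 uM to 10 uM.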

Compound 3, concentration for half-maximal effect: 3.41 uM
Beside the measured number, compound 3's estimate is 1.0-fold (0.01 log units) above it, and the stated range covers the measured number.
By their numbers in this assay, from the lowest: compounds 3 and 2 (each within the scatter of the next); then compound 1.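

Going by these compounds alone, this is the first step in the set that changes a single place, and it tests a methyl on the aromatic carbon that is ortho to a large group and para to a methyl group. In this assay the change from 3-methylphenyl to 2,5-dimethylphenyl gives a 1.1-fold lower number from compound 2 to compound 3 (0.03 log units; within the scatter), so this position takes a methyl with no shift beyond the usual scatter. No supporting data bear on why this is so.

The compounds shown carry only hydrogen or methyl at this position, so it remains open whether a longer chain such as ethyl, an amine or a carboxylic acid there would shift the number. From the compounds shown here alone, whether a methyl at this position would behave the same way on the aryl group of compound 1 also remains open.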